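Aryl variation on the amide nitrogen of the shared core

A few compounds are considered here, and "the series" means these few. Any claim that something is new, unique, unknown or untested is made for them only; others in the source may bear on it.

Compound 1 `O=C(CCc1cccc2c1B(O)OC2)NC1CCCCC1` gives only a limit in a functional assay on HCT-116 cells (Homo sapiens) for antiproliferative activity, read by MTT assay, with a stated time of 72 h (on this read-out higher numbers stand for weaker inhibition and lower numbers for stronger inhibition), > 100000 nM (the limit of > 100000 nM in this assay, at which 1 of the 2 values shown sits). Within the data shown here, compound 2 `O=C(CCc1cccc2c1B(O)OC2)Nc1ccc(I)cc1` gives 50000 nM in this assay, the sole numeric value so far, so no comparison of measured numbers is possible. Among the measured compounds shown here, the step of an at least 2.0-fold lower number from compound 1 to compound 2 (0.30 log units; that floor lies within the scatter) is the only measured step, and its floor sits within the scatter. Compound 3 `O=C(CCc1cccc2c1B(O)OC2)Nc1ccc(-c2ccccc2)cc1` carries phenyl in place of iodo on an aromatic carbon. For the measured compounds named here, no measured step addresses an aryl-for-halogen exchange, so in this assay the expected step is a 1.3-fold lower number from compound 2 to compound 3 (0.10 log units; within the scatter), nothing clearly beyond the scatter. Compound 3 is estimated at 40000 nM in this assay, with a range from 12000 nM to 100000 nM.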

Compound 3, half-maximal inhibitory concentration: 13000 nM
Compound 3: middle estimate off by 3.1-fold (0.49 log units), on the high side, and the stated range covers the measured number.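

Among these compounds, replacing iodo with phenyl on this aromatic carbon gives the first step that clearly exceeds the scatter: in this assay, the result is a 3.8-fold lower number from compound 2 to compound 3 (0.59 log units; beyond the scatter). The only earlier step had a floor within the scatter, so this is the first position shown to respond to a change of group. Compound 1 remains a limit, not a number: the limit of > 100000 nM in this assay, at which 1 of the 3 values shown sits.

Open, going by these compounds, is whether the added ring itself matters, since only iodo and phenyl are compared at this carbon. Also open, on these data alone, is how an amine or a carboxylic acid on the outer phenyl ring would read in this assay.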